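A few compounds are considered here, and "the series" means these few. Any claim that something is new, unique, unknown or untested is made for them only; others in the source may bear on it.

Measured in an ADME assay on microsomes from liver (Homo sapiens) for metabolic stability, read by LC-MS, with a stated time of 10 min; a lower number here means that less of the compound is left, a higher number that more of the compound is left:
Compound 1 `CN(C[C@H]1Cc2c(cccc2N2CCN3CCC[C@H]3C2)CN1)[C@H]1CCCc2cccnc21`: 36.6%
Compound 2 `CN(C[C@H]1Cc2c(cccc2N2CCN3CCC[C@@H]3C2)CN1)[C@H]1CCCc2cccnc21`: 52.2%

Within the data shown here, compound 2 holds the higher of the two numbers, and the only comparison available is a number 15.6 percentage points higher from compound 1 to compound 2 (beyond the scatter). That gap comes with the fact that compounds 1 and 2 differ only in the configuration as drawn.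

Compound 3 `C[C@@H]1CN(c2cccc3c2C[C@H](CN(C)[C@H]2CCCc4cccnc42)NC3)C[C@H](C)N1C` departs from compound 2 in one group on an aromatic carbon: a group of 9 heavy atoms (7 carbon, 2 nitrogen; one six-membered non-aromatic ring with 2 hetero atoms) in place of a group of 9 heavy atoms (7 carbon, 2 nitrogen; one five-membered non-aromatic ring with 1 hetero atom, one six-membered non-aromatic ring with 2 hetero atoms), on an aromatic carbon. The 3,4,5-trimethylpiperazin-1-yl group keeps the six-membered non-aromatic ring with 2 hetero atoms, while the five-membered non-aromatic ring with 1 hetero atom is gone.

Among the measured compounds shown here, no measured step exchanges this group for another. For the measured compounds named here, the single step at this place, the modest one already given, changes configuration alone, so it serves only as a rough guide to size. A change of similar or smaller size is therefore expected in this assay, leaning slightly downward from the 52.2% of compound 2, with a rise not excluded. The expected change is a number 7.2 percentage points lower from compound 2 to compound 3 (within the scatter). For compound 3 the estimated value is 45%, with an expected range from 25% to 65%.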

Compound 3, percent of the compound remaining: 24.6%
Beside the measured number, compound 3's estimate is 20.4 percentage points above it; the measured number lies below the stated range.
By their numbers in this assay, from the lowest: compound 3; then compound 1; then compound 2.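

At this place, on an aromatic carbon of a six-membered aromatic ring of carbon only, the earlier compounds had shown only a change of configuration. The result shows that exchanging the group itself, with the five-membered non-aromatic ring gone and 3,4,5-trimethylpiperazin-1-yl in its place, also moves the number in this assay, with a number 27.6 percentage points lower from compound 2 to compound 3 (beyond the scatter). The direction holds against the other configuration too, with a number 12 percentage points lower from compound 1 to compound 3 (beyond the scatter), so compound 3 stands under both compounds that carry the two-ring group. The two steps start from different numbers because their starting points are not the same stereoisomer: the fact that compounds 1 and 2 differ only in the configuration as drawn

The compounds shown do not separate the loss of the five-membered ring from the methyl groups of the 3,4,5-trimethylpiperazin-1-yl group or from the configuration of its two defined stereocentres. Going by these compounds, how a morpholine or an unsubstituted piperazine would stand at this place also remains open.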